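Bromo added to the ethyl chain of the shared core

The source may report more compounds than this note shows. Statements on the series, on what has been measured and on what is new or still open speak of the compounds shown alone.

Compound 1 has the structure `CCc1cc(=O)c2ccc(OC(C)C)c(CBr)c2o1`. In a functional assay on KB cells (Homo sapiens) for antiproliferative activity, read by sulforhodamine B assay, with a stated time of 72 h (a lower number here means a stronger inhibitor of growth, a higher number a weaker inhibitor of growth), compound 1 gives only a limit of the assay, > 30700 nM. Its near relative compound 2, `CCc1cc(=O)c2ccc(OCC(C)C)c(CBr)c2o1`, carries isobutyl in place of isopropyl on an oxygen on an aromatic ring. In this assay compound 2 likewise gives only a limit, > 29400 nM. The step that the two limits leave unreadable from compound 1 to compound 2 therefore cannot be read, since both values sit at limits (the limit of > 29400 nM in this assay, at which 1 of the 2 values shown sits, and (the limit of > 30700 nM in this assay, at which 1 of the 2 values shown sits)).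

Compound 3, `CC(C)Oc1ccc2c(=O)cc(C(C)Br)oc2c1CBr`, differs from compound 1 in one place: bromo in place of hydrogen on a saturated chain carbon bound to an aromatic carbon and a saturated chain carbon. Read one bond further out, the ethyl becomes 1-bromoethyl. Within the data shown here, no measured step touches this change, and the one measured step, from compound 1 to compound 2, is itself unreadable, so nothing among the measured compounds says how large an effect to expect or in which direction. Only the starting point is known, and that is a limit.

Compound 3 is therefore estimated at 20000 nM in this assay, with a range from 2000 nM to 100000 nM. That estimate means an expected step of an at least 1.5-fold lower number from compound 1 to compound 3 (0.18 log units; that floor lies within the scatter), and it remains a guess until the measurement is made.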

Compound 3, concentration for 50% growth inhibition: 12800 nM
Beside the measured number, compound 3's estimate is 1.6-fold (0.19 log units) above it; measured number inside the range.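

Compound 3 is the first compound shown to give a number rather than a limit in this assay, at 12800 nM, so this carbon of the ethyl chain is the first place in the series where a change can be read. Bromo in place of hydrogen on a saturated chain carbon bound to an aromatic carbon and a saturated chain carbon, which turns ethyl into 1-bromoethyl, gives an at least 2.3-fold lower number from compound 1 to compound 3 (0.37 log units; beyond the scatter). Compound 1 stands at a limit of the assay, so this step gives a floor and no exact size: the limit of > 30700 nM in this assay, at which 1 of the 3 values shown sits.

As far as these compounds go, whether the step belongs to bromo itself stays open, as does whether chloro, hydroxy or an amine on the same carbon would give a step of like size or direction. It also remains open whether 1-bromoethyl would give a similar step with the isobutyl on an oxygen of compound 2, which stands at a limit of the assay: the limit of > 29400 nM in this assay, at which 1 of the 3 values shown sits.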